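Adding Fluoro to Compound 3

The compounds below may be only part of what the source reports. "The series", "measured", "known", "first", "only" and "open" are said of these compounds alone.

In a physicochemical assay for lipophilicity, read by HPLC, using the shake flask method, measured as octanol-water partition, with a stated time of 24 h, at pH 7.4 (a higher number here means a more lipophilic compound, a lower number a more polar compound), compound 3 (`CC(C)=CCn1c(=O)oc2c(C(=O)/C=C/c3ccc(O)cc3)cccc21`) gives 1.65. Compound 1 (`COC(=O)Cn1c(=O)oc2c(C(=O)/C=C/c3ccc(O)cc3)cccc21`), at 1.46, lies within the scatter of that number, while compound 2 (`COC(=O)Cn1c(=O)oc2c(C(=O)/C=C/c3ccc(O)c(F)c3)cccc21`), at 1.31, lies lower by more than the scatter. Compound 4 (`CC(C)=CCn1c(=O)oc2c(C(=O)/C=C/c3ccc(O)c(F)c3)cccc21`) differs from compound 3 by fluoro in place of hydrogen on an aromatic carbon, ortho to a hydroxy group. Within the data shown here, only one measured step makes this same change, a number 0.15 log units lower from compound 1 to compound 2 (within the scatter), and it stays within the scatter. The expected change is therefore small, a number 0.15 log units lower from compound 3 to compound 4 (within the scatter), with no step beyond the scatter foreseen. For compound 4 the estimated value is 1.5, with an expected range of 1.2 to 1.8.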

Compound 4, distribution coefficient: 1.64
The estimate for compound 4 lay 0.14 log units below the measured number, and the stated range covers the measured number.
By their numbers in this assay, from the lowest: compounds 2, 1, 4 and 3 (each within the scatter of the next, the first and the last beyond it).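

Fluoro ortho to a hydroxy group now has a second measured instance on a different side chain, where the result is a number 0.01 log units lower from compound 3 to compound 4 (within the scatter) and agrees with the earlier step of a number 0.15 log units lower from compound 1 to compound 2 (within the scatter) in staying small. With fluoro present, 2-methylprop-1-en-1-yl in place of methoxycarbonyl gives a number 0.33 log units higher from compound 2 to compound 4 (beyond the scatter) while without fluoro it gave a number 0.19 log units higher from compound 1 to compound 3 (within the scatter) on the same change. No evidence at hand gives a cause for these steps.

The compounds shown leave open how chloro or methoxy at this position would read in this assay and how an amine or a carboxylic acid on the chain at the aromatic nitrogen would read there.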